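Nitrooxy to hydroxy on the ether chain: compound 4

The source may hold more compounds than are shown below. What is called first, only, known or untested is meant among the compounds shown, and "the series" means these compounds.

Measured so far in a functional assay on the whole organism (strain Swiss albino) with Mus musculus as the target, in the writhing test, with stated times of 5 min and 10 min; a higher number here means that more compound is needed for the effect, a lower number that less compound is needed:
compound 1 `Cc1c(CCOCCO[N+](=O)[O-])cc(-c2ccc(S(C)(=O)=O)cc2)n1-c1ccccc1` gives 10 mg/kg
compound 2 `Cc1c(CCOCCO[N+](=O)[O-])cc(-c2ccc(S(C)(=O)=O)cc2)n1-c1cccc(F)c1` gives 40 mg/kg
compound 3 `Cc1c(CCOCCCO[N+](=O)[O-])cc(-c2ccc(S(C)(=O)=O)cc2)n1-c1ccccc1` gives 20 mg/kg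

Compound 3 holds the second highest of the three numbers in this assay; its distance to compound 1 and its distance to compound 2 both lie within the scatter, so no order among these three is secure.

Compound 4 `Cc1c(CCOCCCO)cc(-c2ccc(S(C)(=O)=O)cc2)n1-c1ccccc1` differs from compound 3 by hydrogen in place of nitro on an oxygen on a saturated carbon. Neither measured step touches this part of the molecule: a 4.0-fold higher number from compound 1 to compound 2 (0.60 log units; beyond the scatter) concerns the aromatic ring on the nitrogen, and a 2.0-fold higher number from compound 1 to compound 3 (0.30 log units; within the scatter) concerns chain length while the nitrooxy group stays. Nothing in the series shows what loss of the nitro group does here, so the expectation for compound 4 rests on compound 3 alone, with a wide range.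

Compound 4 is therefore expected to give about 30 mg/kg in this assay, between 10 mg/kg and 120 mg/kg. The expected step is a 1.5-fold higher number from compound 3 to compound 4 (0.18 log units; within the scatter), a step whose direction is not supported by any measured pair.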

Compound 4, minimum effective dose: 20 mg/kg
Compound 4: the middle estimate sits 1.5-fold (0.18 log units) above what was measured, and the stated range covers the measured number.
By their numbers in this assay, from the lowest: compounds 1, 3, 4 and 2 (each within the scatter of the next, the first and the last beyond it).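

In this assay, among these compounds, hydrogen in place of nitro on an oxygen on a saturated carbon gives no change at the digits printed from compound 3 to compound 4 (within the scatter), the first direct reading of this change, and the nitrooxy group proves not to be required for activity on this chain. Hydroxymethyl in place of nitrooxy gives a 2.0-fold higher number from compound 1 to compound 4 (0.30 log units; within the scatter), also within the scatter, so neither step separates the hydroxy end group from the nitrooxy end group. Nothing available explains this outcome.

Still open, going by these compounds, is whether an amine, a carboxylic acid or a methyl ether in place of the hydroxy would stay in the same range. Also open, on these data alone, is whether nitrooxy to hydroxy reads the same on the chain of compound 1, or with the fluoro group of compound 2.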